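The source may report more compounds than this note shows. Statements on the series, on what has been measured and on what is new or still open speak of the compounds shown alone.

Compound 1 `CCCCCCCCCC(=O)NCC(C)(C)CC1=C(O)C(=O)c2ccccc2C1=O` and compound 2 `CCCCCCCCCCC(=O)NCC(C)(C)CC1=C(O)C(=O)c2ccccc2C1=O` share one core and differ only in the saturated chain. Going by the values given here, in an ADME assay on Vero cells (Chlorocebus sabaeus) for cytotoxicity, read by reporter gene assay, with a stated time of 4 days (a higher number here means a weaker inhibitor, a lower number a stronger inhibitor), compound 1 gives 15000 nM and compound 2 gives 14900 nM as its reading, so compound 2 stands within the scatter of the only other measured compound. Compound 3 `CCCCCCCCCCCCCCCC(=O)NCC(C)(C)CC1=C(O)C(=O)c2ccccc2C1=O` keeps the same core and carries a longer chain: pentyl in place of hydrogen on a saturated chain carbon, ten or more bonds along the chain from a carbonyl carbon is the whole change. Among the compounds with values here, the one measured step that bears on this is a 1.0-fold lower number from compound 1 to compound 2 (0.00 log units; within the scatter) for a single methyl on the same chain, and it lies within the scatter. One small step says little about a pentyl, so the range has to stay wide, but no step beyond the scatter is expected. The expected size is a 1.1-fold lower number from compound 2 to compound 3 (0.06 log units; within the scatter) by this estimate. For compound 3 the estimated value is 13000 nM with an expected range from 6000 nM to 28000 nM in the same read-out.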

Compound 3, half-maximal inhibitory concentration: 5600 nM
Compound 3: the middle estimate sits 2.3-fold (0.37 log units) above what was measured, and the stated range ends above it.
By their numbers in this assay, from the lowest: compound 3; then compounds 2 and 1 (each within the scatter of the next).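

A pentyl in place of hydrogen on a saturated chain carbon, ten or more bonds along the chain from a carbonyl carbon, does move the reading in this assay: the result is a 2.7-fold lower number from compound 2 to compound 3 (0.42 log units; beyond the scatter), whereas the single methyl on the same chain gave no step beyond the scatter. The hexyl change gives a 2.7-fold lower number from compound 1 to compound 3 (0.43 log units; beyond the scatter) and so shows the same thing from the shorter chain: this far end of the chain can affect the reading once enough carbon is added. Nothing given here explains why the longer chain lowers the number.

Going by these compounds, with so few chain lengths, it stays open where between methyl and pentyl the change sets in, and whether a still longer chain lowers the number further. On these data alone, whether an amine or a carboxylic acid at the chain end would read like the plain chain also stays open.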